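The source may hold more compounds than are shown below. What is called first, only, known or untested is meant among the compounds shown, and "the series" means these compounds.

Measured compounds:
- Compound 1, `N#Cc1c(-c2ccco2)nc2c(c(-c3ccccc3)nn2-c2ccccc2)c1-c1ccc(O)cc1`: 4200 nM
- Compound 2, `N#Cc1c(-c2ccc(F)cc2)nc2c(c(-c3ccccc3)nn2-c2ccccc2)c1-c1ccc(O)cc1`: 10200 nM

In a functional assay on K562 cells (Homo sapiens) for antiproliferative activity, read by resazurin assay, with a stated time of 72 h (a lower number here means a stronger inhibitor, a higher number a weaker inhibitor), compound 2 gives 10200 nM, the highest of the two numbers; its nearest neighbour is compound 1, from which the step of a 2.4-fold higher number from compound 1 to compound 2 (0.39 log units; beyond the scatter) was recorded, a 4-fluorophenyl group replacing furan-2-yl on an aromatic carbon. Compound 3, `Cc1ccc(-c2nc3c(c(-c4ccccc4)nn3-c3ccccc3)c(-c3ccc(O)cc3)c2C#N)cc1`, has not yet been measured. Its difference from compound 2 is methyl in place of fluoro on an aromatic carbon. For the measured compounds named here, the only measured step concerns a different exchange, the replacement of a furan-2-yl ring by a 4-fluorophenyl ring, and does not speak directly to a fluoro-to-methyl swap on that phenyl ring. Going by the values given here, with no step of the same kind available, the exchange of one heavy atom for another on the same carbon is expected to leave the number close to that of compound 2, with a step of a 1.1-fold lower number from compound 2 to compound 3 (0.05 log units; within the scatter) no larger than the scatter. Compound 3 is therefore estimated at 9000 nM in this assay, in a range from 4000 nM to 20000 nM.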

Compound 3, half-maximal inhibitory concentration: 8800 nM
For compound 3 the middle estimate is 1.0-fold (0.01 log units) above the measured one, within the range that was stated.
By their numbers in this assay, from the lowest: compound 1; then compounds 3 and 2 (each within the scatter of the next).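

In this assay, methyl in place of fluoro on the six-membered aromatic ring, para to a large group, gives a 1.2-fold lower number from compound 2 to compound 3 (0.06 log units; within the scatter) and so does not separate these two compounds. The exchange of furan-2-yl for 4-methylphenyl gives a 2.1-fold higher number from compound 1 to compound 3 (0.32 log units; beyond the scatter) and thus goes the same way as the exchange for 4-fluorophenyl, with both phenyl compounds weaker than compound 1 by more than the scatter. No measurement is available that explains either result.

From the compounds shown here alone, whether a group other than fluoro or methyl on this carbon, such as an amine or a carboxylic acid, would shift the number beyond the scatter remains open. So does the question of whether a plain phenyl ring in place of furan-2-yl would give a number like that of compound 1 or those of the two substituted phenyl compounds.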